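From methoxy to a larger fused group

The source may hold more compounds than are shown below. What is called first, only, known or untested is meant among the compounds shown, and "the series" means these compounds.

Measured compounds:
compound 1 `COc1nc2ccc(Cl)cc2c(-c2ccccc2Cl)c1CCO`: 141000 nM
compound 2 `CC(C)(C)[Si](CCc1c(Nn2nnc3ccccc32)nc2ccc(Cl)cc2c1-c1ccccc1Cl)(c1ccccc1)c1ccccc1`: > 1250000 nM

Both were tested in an ADME assay on HepG2 2.2.15 cells (Homo sapiens) for cytotoxicity; on this read-out lower numbers stand for higher toxicity in this test and higher numbers for lower toxicity in this test. Within the data shown here, compound 1 holds the only actual number, 141000 nM. Compound 2 gives only a limit of the assay, > 1250000 nM.

Compound 3 `OCCc1c(Nn2nnc3ccccc32)nc2ccc(Cl)cc2c1-c1ccccc1Cl` has not yet been measured. It differs from compound 1 in one place: a group of 10 heavy atoms (6 carbon, 4 nitrogen; one five-membered aromatic ring with 3 hetero atoms, one six-membered aromatic ring of carbon only) in place of a group of 2 heavy atoms (1 carbon, 1 oxygen; no ring), on an aromatic carbon. Among the measured compounds shown here, the change sits on an aromatic carbon, ortho to a 2-hydroxyethyl group, and no measured step between compounds shows what such a swap does in this assay. Compound 1 at 141000 nM leaves room for the read-out to rise, so a modest upward move, towards lower toxicity in this test, is expected. The expected change is a 2.1-fold higher number from compound 1 to compound 3 (0.33 log units; beyond the scatter). Compound 3 is estimated at 300000 nM, with an expected range from 80000 nM to 1000000 nM.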

Compound 3, half-maximal cytotoxic concentration: 82400 nM
Compound 3: middle estimate off by 3.6-fold (0.56 log units), on the high side, within the range that was stated.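

In this assay, replacing methoxy with the larger fused group on the aromatic carbon next to the ring nitrogen gives a 1.7-fold lower number from compound 1 to compound 3 (0.23 log units; within the scatter). This position therefore accepts a group of 10 heavy atoms with two aromatic rings, with no difference from methoxy that can be told apart from the scatter. Compound 2 gives a limit of the assay rather than a number, and it offers no measured comparison at this position: the limit of > 1250000 nM in this assay, at which 1 of the 3 values shown sits.

The compounds shown leave open how a simple amine or a morpholine ring at this aromatic carbon would read in this assay. They also leave open what a carboxylic acid in place of the hydroxyl end of the 2-hydroxyethyl group would do while the fused group stays in place.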